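The source may hold more compounds than are shown below. What is called first, only, known or untested is meant among the compounds shown, and "the series" means these compounds.

Measured compounds:
Compound 1 `C=C[C@]1(C)C[C@@H](OC(=O)CNC(=O)Nc2ccc(OC)cc2)[C@]2(C)[C@H](C)CC[C@]3(CCC(=O)[C@H]32)[C@@H](C)[C@@H]1O` gives > 10000 nM in a functional assay on MCF7 cells (Homo sapiens) for inhibition, read by MTT assay, with a stated time of 72 h (on this read-out lower numbers stand for stronger inhibition and higher numbers for weaker inhibition), a limit of the assay.
Compound 2 `C=C[C@]1(C)C[C@@H](OC(=O)CNC(=O)NC(=O)c2ccc(Br)cc2)[C@]2(C)[C@H](C)CC[C@]3(CCC(=O)[C@H]32)[C@@H](C)[C@@H]1O` gives > 10000 nM in this assay, again a limit.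
Compound 3 `C=C[C@]1(C)C[C@@H](OC(=O)CNC(=O)Nc2ccc(Cl)cc2)[C@]2(C)[C@H](C)CC[C@]3(CCC(=O)[C@H]32)[C@@H](C)[C@@H]1O` gives > 10000 nM in this assay, also a limit.

Compound 3 therefore stands only at a limit, as do the two other values shown; all three sit at the limit of > 10000 nM in this assay, at which 3 of the 3 values shown sit. The steps a step that the two limits leave unreadable from compound 1 to compound 2, a step that the two limits leave unreadable from compound 1 to compound 3 and a step that the two limits leave unreadable from compound 2 to compound 3 are consequently of unreadable size. Compound 4 `C=C[C@]1(C)C[C@@H](OC(=O)CNC(=O)Nc2ccccc2Br)[C@]2(C)[C@H](C)CC[C@]3(CCC(=O)[C@H]32)[C@@H](C)[C@@H]1O` differs from compound 3 by 2-bromophenyl in place of 4-chlorophenyl on an amide-type nitrogen. Going by the values given here, no measured step bears readably on this change, so no direction beyond the scatter can be taken from the series. Because compound 3 sits at the limit of > 10000 nM in this assay, at which 3 of the 3 values shown sit, compound 4 is expected to remain at or near that limit. Compound 4 is thus estimated at 15000 nM, with a range of 5000 nM to 50000 nM, which means an expected step that the limit leaves unreadable from compound 3 to compound 4.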

Compound 4, half-maximal inhibitory concentration: > 10000 nM
Compound 4 ended at the assay's limit; the forecaster's own chance of this, stated with the estimate: 85%; the middle value is on the limit's open side.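

In this assay, going by these compounds alone, compound 4 gives > 10000 nM, a limit, so no step from compound 1, compound 2 or compound 3 to compound 4 can be read. The compounds shown leave open which change, if any, would give a readable value: the limit of > 10000 nM in this assay, at which 4 of the 4 values shown sit.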